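Methyl in place of hydrogen on a weak binder

The source may hold more compounds than are shown below. What is called first, only, known or untested is meant among the compounds shown, and "the series" means these compounds.

Compound 1 `c1ccc(-c2n[nH]cc2N2CCNCC2)cc1` in an assay on isolated protein for binding affinity to 5-hydroxytryptamine receptor 3A (Homo sapiens) (a higher number here means a weaker inhibitor, a lower number a stronger inhibitor), gives > 10000 nM, which is only a limit of the assay.
Compound 2 `Fc1ccccc1-c1n[nH]cc1N1CCNCC1` gives 1960 nM.
Compound 3 `Fc1cccc(-c2n[nH]cc2N2CCNCC2)c1` gives > 10000 nM, again only a limit.

Compound 1 thus stands at the limit of > 10000 nM in this assay, at which 2 of the 3 values shown sit, and only compound 2 gives a real number. Compound 4 `Cc1ccc(-c2n[nH]cc2N2CCNCC2)cc1` differs from compound 1 by methyl in place of hydrogen on an aromatic carbon. Both measured steps from compound 1 put fluoro in place of hydrogen: an at least 5.1-fold lower number from compound 1 to compound 2 (0.70 log units; beyond the scatter), whereas a step that the two limits leave unreadable from compound 1 to compound 3. Among the compounds with values here, neither step involves a methyl, and the one readable step sits at another place on the ring, so no step of the same kind exists. Compound 4 is expected to show a step that the limit leaves unreadable from compound 1 to compound 4. The estimate for compound 4 is 15000 nM, between 4000 nM and 60000 nM, most probably again only a limit.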

Compound 4, inhibition constant: > 10000 nM
Compound 4 gave a limit, no number (the forecaster's own chance of this, stated with the estimate: 70%); the middle value is on the limit's open side.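

Compound 1 and compound 4 both give only a limit, so no step between them can be read: the limit of > 10000 nM in this assay, at which 3 of the 4 values shown sit.

In this assay the compounds shown leave open whether methyl in place of hydrogen changes binding at all.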